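A fluorophenyl for a chlorophenyl in a weak series

The source may report more compounds than this note shows. Statements on the series, on what has been measured and on what is new or still open speak of the compounds shown alone.

Compound 1 `S=c1oc(-c2ccc3c(c2)OCCO3)nn1CN1CCN(c2cccc(Cl)c2Cl)CC1` and compound 2 `S=c1oc(-c2ccc3c(c2)OCCO3)nn1CN1CCN(c2cccc(Cl)c2)CC1` share one core and differ by a single chloro. In a functional assay on SW 1116 cells (Homo sapiens) for antiproliferative activity, read by MTT assay, with a stated time of 48 h (a lower number here means a stronger inhibitor, a higher number a weaker inhibitor), compound 1 gives 37100 nM. For compound 2 this assay reports only a limit, > 50000 nM. The step of an at least 1.3-fold higher number from compound 1 to compound 2 (0.12 log units; that floor lies within the scatter) therefore rests on the limit of > 50000 nM in this assay, at which 1 of the 2 values shown sits, and lies within the scatter. Compound 3 `Fc1ccc(N2CCN(Cn3nc(-c4ccc5c(c4)OCCO5)oc3=S)CC2)cc1` carries 4-fluorophenyl in place of 3-chlorophenyl on an amine nitrogen in a ring. For the measured compounds named here, no measured step tests this exchange; the one step known, an at least 1.3-fold higher number from compound 1 to compound 2 (0.12 log units; that floor lies within the scatter), was small, so no change beyond the scatter is expected in this assay. Compound 3 is expected at 55000 nM, between 20000 nM and 150000 nM, a step that the limit leaves unreadable from compound 2 to compound 3, most likely again reported as a limit.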

Compound 3, half-maximal inhibitory concentration: > 50000 nM
Compound 3: only a limit was reported (the forecaster's own chance of this, stated with the estimate: 60%); the middle value is on the limit's open side.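

In this assay, compound 3 gives only a limit, > 50000 nM, so the exchange of 3-chlorophenyl for 4-fluorophenyl on an amine nitrogen in a ring cannot be read against compound 2. For the compounds shown here, the one readable step, an at least 1.3-fold higher number from compound 1 to compound 3 (0.12 log units; that floor lies within the scatter), shows no change beyond the scatter. Compound 1 therefore remains the only compound here with a number, and the rest share one ceiling: the limit of > 50000 nM in this assay, at which 2 of the 3 values shown sit.

Going by these compounds, whether any group at this nitrogen moves activity beyond the scatter stays open. A 4-chlorophenyl or an unsubstituted phenyl might give a value below the limit.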